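A few compounds are considered here, and "the series" means these few. Any claim that something is new, unique, unknown or untested is made for them only; others in the source may bear on it.

Notes on the anilino series sharing the core of compound 1 `CC(C)c1ccc(-c2nc(SCc3cn(CC(=O)NC(=O)Nc4ccccn4)nn3)nc(Nc3ccc(Cl)cc3)c2C#N)cc1`.

In a functional assay on MCF7 cells (Homo sapiens) for inhibition, read by MTT assay, with a stated time of 72 h (on this read-out higher numbers stand for weaker inhibition and lower numbers for stronger inhibition), compound 1 gives only a limit, > 64000 nM, and not a number. Compound 2 `CC(C)c1ccc(-c2nc(SCc3cn(CC(=O)NC(=O)Nc4ccccn4)nn3)nc(Nc3cccc(Cl)c3)c2C#N)cc1`, carrying 3-chlorophenyl in place of 4-chlorophenyl on a nitrogen on an aromatic ring, gives 18000 nM in this assay, so that an at least 3.5-fold lower number from compound 1 to compound 2 (0.55 log units; beyond the scatter). Compound 3 `CC(C)c1ccc(-c2nc(SCc3cn(CC(=O)NC(=O)Nc4ccccn4)nn3)nc(Nc3ccccc3F)c2C#N)cc1`, with 2-fluorophenyl on that nitrogen, again gives only a limit, > 64000 nM. Accordingly an at least 3.5-fold higher number from compound 2 to compound 3 (0.55 log units; beyond the scatter), while a step that the two limits leave unreadable from compound 1 to compound 3, since both ends sit at the limit of > 64000 nM in this assay, at which 2 of the 3 values shown sit.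

Compound 4 `COc1ccc(Nc2nc(SCc3cn(CC(=O)NC(=O)Nc4ccccn4)nn3)nc(-c3ccc(C(C)C)cc3)c2C#N)cc1` differs from compound 1 in one place: methoxy in place of chloro on an aromatic carbon. Going by the values given here, none of the measured steps changes a group at this carbon while keeping the ring pattern of compound 1; each moves a halogen to another carbon of the aromatic ring, so none bears directly on the change to compound 4. Among the compounds with values here, what the numbers show is that compound 1 sits at the limit and that only one of the three compounds gives a number at all.

Within the data shown here, with no measured step to lean on, compound 4 is expected to stay near compound 1, and its number in this assay is estimated at 45000 nM, within 12000 nM to 150000 nM. The expected step is therefore an at least 1.4-fold lower number from compound 1 to compound 4 (0.15 log units; that floor lies within the scatter).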

Compound 4, half-maximal inhibitory concentration: > 64000 nM
Compound 4: no number, only a limit (the forecaster's own chance of this, stated with the estimate: 60%); at least 1.4-fold (0.15 log units) between middle value and limit.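

In this assay compound 4 gives > 64000 nM, which is a limit. The steps to compound 4 from compound 1 and from compound 3 cannot be read, so the exchange of chloro for methoxy on this aromatic carbon has no measurable size here. The one readable step is an at least 3.5-fold higher number from compound 2 to compound 4 (0.55 log units; beyond the scatter), and the limit now extends to a group other than a halogen on the anilino ring, leaving compound 2 as the only compound with a number: the limit of > 64000 nM in this assay, at which 3 of the 4 values shown sit.

Still open, going by these compounds, is whether any group on this aromatic carbon gives a number at all, for example an amine or a carboxylic acid in place of methoxy. Also open, on these data alone, is whether the number of compound 2 depends on its chloro group, which could be tested by methoxy or an amine in place of chloro on the ring of compound 2.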